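Aryl swap on the piperazine with the three-carbon linker

The source may report more compounds than this note shows. Statements on the series, on what has been measured and on what is new or still open speak of the compounds shown alone.

Measured so far in an assay on HEK293 cells for inhibition of Voltage-dependent T-type calcium channel subunit alpha-1G (Homo sapiens), read by patch clamp; on this read-out lower numbers stand for stronger inhibition and higher numbers for weaker inhibition:
compound 1 `CCCc1nc(-c2ccccc2)c(CNCCN2CCN(c3ccc(Cl)cc3)CC2)o1`: 2820 nM
compound 2 `CCCc1nc(-c2ccccc2)c(CNCCCN2CCN(c3cccc(C(F)(F)F)c3)CC2)o1`: 650 nM
compound 3 `CCCc1nc(-c2ccccc2)c(CNCCN2CCN(c3cccc(F)c3)CC2)o1`: 3350 nM

Compound 2 shows the lowest number of the three; compound 1 and compound 3 both sit well above it, and each of those gaps lies beyond the scatter. Compound 2 differs from the other two in both the linker and the aryl group, so the values alone do not show which part carries that gap.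

Compound 4 `CCCc1nc(-c2ccccc2)c(CNCCCN2CCN(c3ccccc3F)CC2)o1` keeps the three-carbon linker of compound 2 and changes only the aryl group: 2-fluorophenyl in place of 3-(trifluoromethyl)phenyl on an amine nitrogen in a ring. Within the data shown here, the one measured step that bears on an aryl change on this nitrogen is a 1.2-fold higher number from compound 1 to compound 3 (0.07 log units; within the scatter), a halogen swap on the shorter linker that left the number essentially where it was. Going by these compounds, on that basis little movement is expected in this assay from compound 2 to compound 4, though the switch from a trifluoromethyl-bearing ring to a fluorine-bearing one is untested on this linker, and the two compounds with fluorine or chlorine alone sit higher. The expected step is a 2.0-fold higher number from compound 2 to compound 4 (0.30 log units; within the scatter), a modest rise. Compound 4 is estimated at 1300 nM, with a likely range from 500 nM to 3500 nM.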

Compound 4, half-maximal inhibitory concentration: 16100 nM
Compound 4: the middle estimate sits 12-fold (1.09 log units) below what was measured; the whole stated range lies below it.
By their numbers in this assay, from the lowest: compound 2; then compounds 1 and 3 (each within the scatter of the next); then compound 4.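

In this assay, the step on the three-carbon linker is large: a 25-fold higher number from compound 2 to compound 4 (1.39 log units; beyond the scatter), with 2-fluorophenyl in place of 3-(trifluoromethyl)phenyl on the amine nitrogen in a ring. Among these compounds, the aryl group at this position can therefore move the number well beyond the scatter with the linker and the rest of the molecule held fixed, whereas the only earlier aryl step, on the shorter linker, was flat at a 1.2-fold higher number from compound 1 to compound 3 (0.07 log units; within the scatter). Aryl changes at this position cannot be treated as generally silent in this series, and nothing on hand bears on why this one moves the number so far.

Going by these compounds, compound 4 changes both the substituent and its place on the phenyl ring at once, so it remains open whether the large step follows the loss of trifluoromethyl or the new substituent position. On these data alone, a 2-(trifluoromethyl)phenyl or an unsubstituted phenyl on the three-carbon linker would help separate the two, and the effect of linker length with the aryl group held constant also remains open.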